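Aryl replacement on the core of compound 1

The source may report more compounds than this note shows. Statements on the series, on what has been measured and on what is new or still open speak of the compounds shown alone.

Measured compounds in a functional assay on HeLa cells (Homo sapiens) for inhibition, read by CCK-8 assay, with a stated time of 48 h; on this read-out lower numbers stand for stronger inhibition and higher numbers for weaker inhibition:
compound 1 `COc1cc(-c2ccnc3cc(-c4ccc(Cl)cc4)nn23)cc(OC)c1OC`: 1490 nM
compound 2 `COc1cc(-c2ccnc3cc(-c4ccc(C)c(C)c4)nn23)cc(OC)c1OC`: 241 nM
compound 3 `COc1cc(-c2ccnc3cc(-c4ccc(N(C)C)cc4)nn23)cc(OC)c1OC`: 378 nM

Compound 1 gives the highest number of the three. Both steps away from it replace the 4-chlorophenyl with a differently substituted aryl group on the same carbon of the shared core and both lower the number beyond the scatter: a 6.2-fold lower number from compound 1 to compound 2 (0.79 log units; beyond the scatter) and a 3.9-fold lower number from compound 1 to compound 3 (0.60 log units; beyond the scatter). The step of a 1.6-fold higher number from compound 2 to compound 3 (0.20 log units; within the scatter) stays within the scatter, so compound 2 and compound 3 are not told apart on this read-out.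

Compound 4 `COc1cc(-c2ccnc3cc(-c4ccc5ccn(C)c5c4)nn23)cc(OC)c1OC` differs from compound 1 by 1-methyl-1H-indol-6-yl in place of 4-chlorophenyl on an aromatic carbon. This is again an exchange of the aryl group on the core, now for 1-methyl-1H-indol-6-yl. For the measured compounds named here, the two measured exchanges at this position both gave a modest lowering of the number, and nothing among the measured compounds points the other way. A lowering of comparable size is therefore expected in this assay for compound 4, with the usual uncertainty that an untested group carries. Compound 4 is estimated at 350 nM, within a range of 120 nM to 1200 nM. This estimate corresponds to an expected step of a 4.3-fold lower number from compound 1 to compound 4 (0.63 log units; beyond the scatter).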

Compound 4, half-maximal inhibitory concentration: 187 nM
Beside the measured number, compound 4's estimate is 1.9-fold (0.27 log units) above it; the range from low to high includes it.
By their numbers in this assay, from the lowest: compounds 4, 2 and 3 (each within the scatter of the next, the first and the last beyond it); then compound 1.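

In this assay, the gain over the 4-chlorophenyl compound is not confined to substituted phenyl groups: an 8.0-fold lower number from compound 1 to compound 4 (0.90 log units; beyond the scatter) shows that this aromatic carbon also accepts 1-methyl-1H-indol-6-yl, which brings a five-membered aromatic ring with 1 hetero atom alongside the six-membered carbon ring. The new group also separates from one of the earlier replacements but not from the other: a 2.0-fold lower number from compound 3 to compound 4 (0.31 log units; beyond the scatter) lies beyond the scatter, whereas a 1.3-fold lower number from compound 2 to compound 4 (0.11 log units; within the scatter) stays within it, so the 3,4-dimethylphenyl and 1-methyl-1H-indol-6-yl groups cannot be ranked on this read-out. No available evidence bears on the reason for these differences.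

Open, as far as these compounds go, is whether the methyl on the indole nitrogen contributes at all, which the unsubstituted 1H-indol-6-yl group would test, and whether the attachment point on the indole matters, as a 1-methyl-1H-indol-5-yl group would show. Also open, from the compounds shown here alone, is how far this position tolerates a phenyl ring carrying a carboxylic acid or a morpholine, and whether these aryl preferences hold when the other aryl group on the shared core is changed.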